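This account rests on a few compounds, and the source may have more. Where it says the series, first, only, none or still open, it means among the compounds named here.

Working notes on the series. Compound 2 `COc1ccccc1CNCCCNS(=O)(=O)c1cc(C(F)(F)F)cc(C(F)(F)F)c1` gives 2400 nM in a functional assay on HPAC cells (Homo sapiens) for inhibition, read by MTT assay, with a stated time of 72 h; on this read-out higher numbers stand for weaker inhibition of growth and lower numbers for stronger inhibition of growth. Compound 1 `CC(C)(C)c1ccc(CNCCCNS(=O)(=O)c2cc(C(F)(F)F)cc(C(F)(F)F)c2)cc1` gives 2300 nM in this assay, and the two numbers sit within the scatter of each other, so compound 2 stands alongside compound 1 rather than apart from it.

The next compound, compound 3 `COc1ccc(CNCCCNS(=O)(=O)c2cc(C(F)(F)F)cc(C(F)(F)F)c2)cc1`, differs from compound 2 by 4-methoxyphenyl in place of 2-methoxyphenyl on a saturated chain carbon bound to an amine nitrogen. For the measured compounds named here, no measured step moves a methoxy group around this ring. Going by the values given here, the only step on this part of the shared core, a 1.0-fold higher number from compound 1 to compound 2 (0.02 log units; within the scatter), exchanges a whole aryl group and stays within the scatter, which suggests that this position tolerates variation without a shift in this assay. On that basis the step of a 1.0-fold lower number from compound 2 to compound 3 (0.02 log units; within the scatter) is expected to be small, with no direction beyond the scatter. Compound 3 is therefore estimated at 2300 nM in this assay, in the range 1000 nM to 5500 nM.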

Compound 3, concentration for 50% growth inhibition: 3000 nM
Compound 3: the middle estimate sits 1.3-fold (0.12 log units) below what was measured; the measured number falls inside the stated range.
By their numbers in this assay, from the lowest: compounds 1, 2 and 3 (each within the scatter of the next).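

In this assay, 4-methoxyphenyl in place of 2-methoxyphenyl gives a 1.3-fold higher number from compound 2 to compound 3 (0.10 log units; within the scatter), so the series now holds a direct comparison of two places of the methoxy group on this ring, and it stays within the scatter. Methoxy in place of tert-butyl on an aromatic carbon gives a 1.3-fold higher number from compound 1 to compound 3 (0.12 log units; within the scatter), also within the scatter, so the exchange at the ring's 4-position does not separate compound 1 and compound 3 either. No evidence accompanies these numbers that could account for this flat picture.

Going by these compounds, whether a carboxylic acid on this ring, or a pyridine ring in place of the methoxyphenyl, would also stay within the scatter remains open. The response to a longer chain in the shared core is open as well.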